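The compounds below may be only part of what the source reports. "The series", "measured", "known", "first", "only" and "open" are said of these compounds alone.

Compound 1 `Nc1nc(O)c2c(n1)n(C1OC(CO)[C@@H](O)[C@H]1O)c(=O)n2CC(O)CSc1ccccc1` and compound 2 `NC(=O)Cn1c(=O)n(C2OC(CO)[C@@H](O)[C@H]2O)c2nc(N)nc(O)c21` share a core and differ only at a saturated chain carbon bound to an aromatic nitrogen. In a functional assay (B cells) with Mus musculus as the target (a higher number here means that more compound is needed for the effect, a lower number that less compound is needed), compound 1 gives 142 uM and compound 2 gives 190 uM. The step of a 1.3-fold higher number from compound 1 to compound 2 (0.13 log units; within the scatter) changed little. Compound 2 holds the higher of the two numbers, a gap that lies within the scatter. Compound 3 `Nc1nc(O)c2c(n1)n(C1OC(CO)[C@@H](O)[C@H]1O)c(=O)n2Cc1ccccc1` carries the change (phenyl in place of carbamoyl on a saturated chain carbon bound to an aromatic nitrogen). For the measured compounds named here, only the step from compound 1 to compound 2 bears on this position, and it stayed within the scatter, so the expected step is no change at the digits printed from compound 2 to compound 3 (within the scatter). Compound 3 is expected to give 190 uM, within 80 uM to 450 uM.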

Compound 3, concentration for half-maximal effect: 6 uM
The estimate for compound 3 lay 32-fold (1.50 log units) above the measured number; measured number below the stated range.
By their numbers in this assay, from the lowest: compound 3; then compounds 1 and 2 (each within the scatter of the next).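

Phenyl in place of carbamoyl on a saturated chain carbon bound to an aromatic nitrogen brings a 32-fold lower number from compound 2 to compound 3 (1.50 log units; beyond the scatter) in this assay, and phenyl in place of 1-hydroxy-2-(phenylsulfanyl)ethyl brings a 24-fold lower number from compound 1 to compound 3 (1.37 log units; beyond the scatter), so this position can move the number strongly. Compound 1 also holds a phenyl ring, within its 1-hydroxy-2-(phenylsulfanyl)ethyl group, yet it stays within the scatter of compound 2, so a phenyl ring alone does not go with the low number. Nothing available explains this step. Open, on these data alone, is how a cyclohexyl group, a pyridine ring or a longer chain such as phenethyl would read at this position.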